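Benzyloxy swap on the shared core: compound 4

This account rests on a few compounds, and the source may have more. Where it says the series, first, only, none or still open, it means among the compounds named here.

Compound 2 `Cc1cc(C)cc(COc2ccc(-c3cc(CN4CCN(Cc5ccc(C(F)(F)F)cc5)CC4)no3)cc2)c1` gives the lowest number of the three measured in a functional assay on Huh-7 cells (Homo sapiens) for antiproliferative activity, read by sulforhodamine B assay, with a stated time of 72 h (a higher number here means a weaker inhibitor, a lower number a stronger inhibitor), at 600 nM. Compound 3 `Fc1ccccc1COc1ccc(-c2cc(CN3CCN(Cc4ccc(C(F)(F)F)cc4)CC3)no2)cc1` gives 1500 nM, and compound 1 `Cc1cccc(COc2ccc(-c3cc(CN4CCN(Cc5ccc(C(F)(F)F)cc5)CC4)no3)cc2)c1` gives 5000 nM. Compound 4 `Fc1cccc(COc2ccc(-c3cc(CN4CCN(Cc5ccc(C(F)(F)F)cc5)CC4)no3)cc2)c1` differs from compound 2 by 3-fluorophenyl in place of 3,5-dimethylphenyl on a saturated chain carbon bound to an oxygen on an aromatic ring. Among the compounds with values here, three steps bear on this: a 2.5-fold higher number from compound 2 to compound 3 (0.40 log units; beyond the scatter); a 3.3-fold lower number from compound 1 to compound 3 (0.52 log units; beyond the scatter); and an 8.3-fold lower number from compound 1 to compound 2 (0.92 log units; beyond the scatter). Loss of both methyl groups went with a higher number, whereas a fluorophenyl in place of a methylphenyl went with a lower one; no measured compound carries 3-fluorophenyl, so the two pulls cannot be separated. A modest upward step in this assay is therefore expected for compound 4, a 2.0-fold higher number from compound 2 to compound 4 (0.30 log units; within the scatter), estimated at 1200 nM with a range from 500 nM to 3000 nM.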

Compound 4, half-maximal inhibitory concentration: 1300 nM
For compound 4 the middle estimate is 1.1-fold (0.03 log units) below the measured one; low and high end bracket the measured number.
By their numbers in this assay, from the lowest: compound 2; then compounds 4 and 3 (each within the scatter of the next); then compound 1.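

In this assay, 3-fluorophenyl and 2-fluorophenyl on the saturated chain carbon bound to an oxygen on an aromatic ring cannot be told apart (a 1.2-fold lower number from compound 3 to compound 4 (0.06 log units; within the scatter)). Fluoro in place of methyl on an aromatic carbon goes with a lower number (a 3.8-fold lower number from compound 1 to compound 4 (0.59 log units; beyond the scatter)), yet 3,5-dimethylphenyl stays ahead of 3-fluorophenyl (a 2.2-fold higher number from compound 2 to compound 4 (0.34 log units; beyond the scatter)). No measured evidence accounts for these steps.

Still open, on these data alone, is how 3,5-difluorophenyl or a methoxy-substituted phenyl at this place would compare with 3,5-dimethylphenyl.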